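This account rests on a few compounds, and the source may have more. Where it says the series, first, only, none or still open, it means among the compounds named here.

Working notes on the series, read in a functional assay on A549 cells (Homo sapiens) for inhibition, read by MTT assay, with a stated time of 72 h; a lower number here means a stronger inhibitor, a higher number a weaker inhibitor. Compound 1 `CCC/C=C\C(=O)Nc1cc(Nc2nc3c(c(-c4cn(C)c5ccccc45)n2)CSCC3)c(OC)cc1N(C)CCN(C)C` gives 571 nM and compound 2 `COc1cc(N(C)CCN(C)C)c(NC(=O)C=C(C)C)cc1Nc1nc2c(c(-c3cn(C)c4ccccc34)n1)CS(=O)(=O)CC2` gives 787 nM, two values within the scatter of each other. Compound 3 `COc1cc(N(C)CCN(C)C)c(NC(=O)C=C(C)C)cc1Nc1nc2c(c(-c3cn(C)c4ccc(F)cc34)n1)CS(=O)(=O)CC2` gives 2140 nM, the highest of the three numbers and so the weakest inhibitor measured so far.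

Compound 4 `CCC/C=C\C(=O)Nc1cc(Nc2nc3c(c(-c4cn(C)c5ccc(F)cc45)n2)CS(=O)(=O)CC3)c(OC)cc1N(C)CCN(C)C` departs from compound 3 by a single change: pent-1-en-1-yl in place of 2-methylprop-1-en-1-yl on a carbonyl carbon. Among the compounds with values here, no measured step isolates this swap. Within the data shown here, the one measured step, a 2.7-fold higher number from compound 2 to compound 3 (0.43 log units; beyond the scatter), is modest and concerns fluoro in place of hydrogen on an aromatic carbon, a different change, which compound 4 retains. Compound 1 carries pent-1-en-1-yl and compound 2 carries 2-methylprop-1-en-1-yl, but the two differ elsewhere too, so their values offer only an indirect hint. On that thin evidence, no step beyond the scatter is expected in this assay. The expected step is a 1.2-fold lower number from compound 3 to compound 4 (0.08 log units; within the scatter). For compound 4 the estimated value is 1800 nM, with an expected range of 700 nM to 4500 nM.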

Compound 4, half-maximal inhibitory concentration: 7570 nM
Compound 4: middle estimate off by 4.2-fold (0.62 log units), on the low side, and the stated range ends below it.
By their numbers in this assay, from the lowest: compounds 1 and 2 (each within the scatter of the next); then compound 3; then compound 4.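

In this assay, within the data shown here, the first measured swap at this position, pent-1-en-1-yl in place of 2-methylprop-1-en-1-yl on a carbonyl carbon, gives a 3.5-fold higher number from compound 3 to compound 4 (0.55 log units; beyond the scatter) and so shows that the group on this carbonyl carbon also moves the number, whereas the earlier step, a 2.7-fold higher number from compound 2 to compound 3 (0.43 log units; beyond the scatter), concerned a different place. Both groups are all-carbon with no ring, so a change confined to such a chain is enough for a step beyond the scatter, here towards weaker inhibition. Nothing shown here accounts for this shift.

On these data alone, whether the same swap gives a similar step in compounds without the fluoro group remains open, as the step is read only with the fluoro group present. Also open, as far as these compounds go, is how a longer chain or an amine-bearing chain would read on this carbonyl carbon.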